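Halogen Swap on the Benzyl Ether and Cytotoxicity

The source may report more compounds than this note shows. Statements on the series, on what has been measured and on what is new or still open speak of the compounds shown alone.

Measured so far in an ADME assay on HEL cells (Homo sapiens) for cytotoxicity, with a stated time of 3 days; a lower number here means that less compound is tolerated, a higher number that more compound is tolerated:
Compound 1, `CCC1(Cc2ccccc2)OS(=O)(=O)C=C1OS(=O)(=O)c1ccc(C)cc1`, gives 400000 nM.
Compound 2, `CCC1(Cc2ccccc2)OS(=O)(=O)C=C1OCc1ccccc1Cl`, gives only a limit, >= 20000 nM.

Compound 1 stands at a measured number in this assay, while compound 2 stands at a limit of the assay and not at a number, as the limit of >= 20000 nM in this assay, at which 1 of the 2 values shown sits, records. For the measured compounds named here, no step between the two is given, so only the two values themselves can be compared, and they say nothing firm about the change from the first to the second.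

Compound 3, `CCC1(Cc2ccccc2)OS(=O)(=O)C=C1OCc1ccc(Br)cc1`, has not yet been measured. It differs from compound 2 in one place: 4-bromophenyl in place of 2-chlorophenyl on a saturated chain carbon bound to an oxygen on an unsaturated carbon. On the numbers shown, nothing points to a step beyond the usual scatter, so the expected step that the limit leaves unreadable from compound 2 to compound 3 is small in either direction. Compound 3 is therefore estimated at 40000 nM, within a range of 10000 nM to 200000 nM, with a fair chance that the assay again reports only a limit.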

Compound 3, minimum cytotoxic concentration: 80000 nM
The estimate for compound 3 lay 2.0-fold (0.30 log units) below the measured number; the measured number falls inside the stated range.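

For the compounds shown here, no step from compound 2 to compound 3 can be read in this assay, since compound 2 stands at a limit and not at a number: the limit of >= 20000 nM in this assay, at which 1 of the 3 values shown sits. The compounds shown leave open whether 4-bromophenyl in place of 2-chlorophenyl shifts the tolerated concentration at all, and in which direction.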